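Benzyl for cyclopentyl on the amine of compound 3

The compounds below may be only part of what the source reports. "The series", "measured", "known", "first", "only" and "open" are said of these compounds alone.

Compound 1 `Nc1ncc(-c2cccc(F)c2)c(-c2ccccc2)n1` gives 63% in an assay on CHO cells for displacement of a labelled ligand from adenosine receptor A1 (Homo sapiens), read by scintillation counting, with a stated time of 1 h, tested at 1 uM; on this read-out higher numbers stand for more inhibition at the one concentration tested (going by the name of the read-out) and lower numbers for less inhibition. Compound 2 `Nc1ncc(-c2ccc(O)c(Cl)c2)c(-c2ccccc2)n1` reaches > 80% in this assay, which is a limit of the read-out and not a number. Compound 3 `Clc1cccc(-c2cnc(NC3CCCC3)nc2-c2ccccc2)c1` likewise sits at > 80% in this assay, again a limit rather than a number. Compound 3 therefore stands at the limit of > 80% in this assay, at which 2 of the 3 values shown sit, the top of what this read-out reports. Compound 4 `Clc1cccc(-c2cnc(NCc3ccccc3)nc2-c2ccccc2)c1` carries benzyl in place of cyclopentyl on a nitrogen on an aromatic ring. Within the data shown here, no step between measured compounds separates these two, so nothing shows how this exchange moves the read-out. With compound 3 at the limit, compound 4 is expected to stay near it, and a step of a number at least 5 percentage points lower from compound 3 to compound 4 (that floor lies within the scatter) is estimated. Compound 4 is expected at 75%, within 50% to 88%.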

Compound 4, a percentage reported as inhibition, at one concentration (the size of the read-out at that concentration, not a potency): 16%
For compound 4 the middle estimate is 59 percentage points above the measured one; measured number below the stated range.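

The amine nitrogen proves sensitive in this assay, as benzyl in place of cyclopentyl gives a number at least 64 percentage points lower from compound 3 to compound 4 (beyond the scatter), so a carbon-only ring on this nitrogen does not by itself keep the read-out high. On these data alone, the true size of this step stays unknown, since compound 3 stands at a limit and not a number: the limit of > 80% in this assay, at which 2 of the 4 values shown sit. As far as these compounds go, whether the drop follows from the aromatic ring or from the extra carbon linking it to the nitrogen remains open. A cyclohexylmethyl or phenethyl group on this nitrogen would separate the two.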